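Oxime ether chain change in the diaryl sulfide series

This account rests on a few compounds, and the source may have more. Where it says the series, first, only, none or still open, it means among the compounds named here.

Among the compounds with values here, compound 1 `C/C(=N\OCCSc1nnnn1C)c1ccc(Sc2cc(F)cc(C3CCOCC3)c2)cc1` holds the only number in this set for a functional assay (blood) for inhibition, with Homo sapiens as the target (a higher number here means a weaker inhibitor, a lower number a stronger inhibitor), where compound 1 gives 120 nM. Compound 2 `C/C(=N\O)c1ccccc1Sc1cc(F)cc(C2CCOCC2)c1` gives > 10000 nM in this assay, which is a limit of the assay and not a number (the limit of > 10000 nM in this assay, at which 1 of the 2 values shown sits). Within the data shown here, no pair of measured compounds differs in a single place, so these two values stand on their own and support no step.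

Compound 3 `COC(=O)C(C)(C)CO/N=C(\C)c1ccc(Sc2cc(F)cc(C3CCOCC3)c2)cc1` is not yet measured. It differs from compound 1 by 1-(methoxycarbonyl)-1-methylethyl in place of ((1-methyl-1H-tetrazol-5-yl)sulfanyl)methyl on a saturated chain carbon bound to an oxygen. The shared core of compound 1 is kept, and the change lies on the oxime ether chain.

The expected step of a 2.1-fold higher number from compound 1 to compound 3 (0.32 log units; beyond the scatter) in this assay is modest, toward a weaker inhibitor, and may not exceed the usual scatter. Compound 3 is estimated at 250 nM in this assay, with a range from 60 nM to 1000 nM.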

Compound 3, half-maximal inhibitory concentration: 420 nM
For compound 3 the middle estimate is 1.7-fold (0.23 log units) below the measured one; measured number inside the range.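

The oxime ether chain now has its first readable step: in this assay, 2-(methoxycarbonyl)-2-methylpropyl in place of 2-((1-methyl-1H-tetrazol-5-yl)sulfanyl)ethyl gives a 3.5-fold higher number from compound 1 to compound 3 (0.54 log units; beyond the scatter). With no ring in the entering group, compound 3 still gives 420 nM, so the five-membered aromatic ring with 4 hetero atoms and the sulfur are not required for a measured number at this position. No measurement shown gives a cause for this step.

From the compounds shown here alone, this one change replaces the ring, the sulfur and the chain branching together with the ester, so which of these parts carries the step remains open. Also open, going by these compounds, is whether a carboxylic acid in place of the methoxycarbonyl group, or a longer chain, would move the number at this position, and in which direction.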